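The compounds below may be only part of what the source reports. "The series", "measured", "known", "first", "only" and "open" are said of these compounds alone.

Compound 1, `CCOc1cccc(-c2ccc([C@H]3S[C@@H](C)C(=O)Nc4c3c(C)nn4-c3ccccc3C)cc2)c1`: 13%
Compound 2, `Cc1nn(-c2ccccc2C(F)(F)F)c2c1C(c1ccc(Oc3ccccc3)cc1)SC(C)C(=O)N2`: 50%
Compound 3, `COc1ccccc1-n1nc(C)c2c1NC(=O)[C@H](C)S[C@@H]2c1ccc(Oc2ccccc2)cc1`: 37%

In an assay on isolated protein for agonist activity at Bile acid receptor (Homo sapiens), read by AlphaScreen, with a stated time of 30 min (a lower number here means a smaller maximal response, a higher number a larger maximal response), compound 3 gives 37%, the second highest of the three numbers. The nearest number is that of compound 2, which lies higher by more than the scatter; the furthest is that of compound 1, which lies lower by more than the scatter. Among the measured compounds shown here, the three compounds differ from one another in more than one place, so no single step between measured compounds can be read from them.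

Compound 4, `Cc1cccc(-n2nc(C)c3c2NC(=O)[C@H](C)S[C@@H]3c2ccc(Oc3ccccc3)cc2)c1`, has not yet been measured in this assay. It differs from compound 3 in one place: 3-methylphenyl in place of 2-methoxyphenyl on an aromatic nitrogen. For the measured compounds named here, no measured pair shows this change on its own, so the expectation for compound 4 rests only on the spread of the three numbers. The step is expected to be small, with no clear direction, and may well stay within the scatter: a number 3 percentage points higher from compound 3 to compound 4 (within the scatter). Compound 4 is therefore estimated to reach 40% in this assay, within a range from 22% to 58%.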

Compound 4, largest response reached (reported as efficacy), in percent of the reference or control that the assay uses: 22%
Compound 4: middle estimate off by 18 percentage points, on the high side; low and high end bracket the measured number.
By their numbers in this assay, from the lowest: compounds 1 and 4 (each within the scatter of the next); then compound 3; then compound 2.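

In this assay, among the compounds shown here, the exchange of 2-methoxyphenyl for 3-methylphenyl on the aromatic nitrogen is the first single change that can be read, and it brings a number 15 percentage points lower from compound 3 to compound 4 (beyond the scatter) with the rest of the structure held fixed. The maximal response therefore depends on which substituted phenyl group sits at this position, and this change lowers it by more than the usual scatter. Nothing available gives a cause for this step.

The compounds shown leave open whether the loss of the oxygen or the move of the substituent around the phenyl ring carries the step, as the two go together here. As far as these compounds go, how an amine or a carboxylic acid on this phenyl ring, or a pyridine ring in its place, would affect the response also remains open.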